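Working notes: from compound 3 to compound 4

The source may report more compounds than this note shows. Statements on the series, on what has been measured and on what is new or still open speak of the compounds shown alone.

Values in a functional assay on KB cells (Homo sapiens) for cytotoxicity, read by MTT assay, with a stated time of 72 h (on this read-out lower numbers stand for stronger inhibition and higher numbers for weaker inhibition), follow
- compound 1 `Cc1ccc(S(=O)(=O)c2nc3ccccc3nc2N2CCc3ccccc3C2)cc1` gives 32100 nM
- compound 2 `COc1ccc(S(=O)(=O)c2nc3ccccc3nc2N2CCc3ccccc3C2)cc1` gives > 50000 nM as a limit
- compound 3 `O=S(=O)(c1ccc(F)cc1)c1nc2ccccc2nc1N1CCc2ccccc2C1` gives 35400 nM

Compound 3 stands within the scatter of compound 1 with a 1.1-fold higher number from compound 1 to compound 3 (0.04 log units; within the scatter) as the step between them. The comparison that rests on a limit gives an at least 1.4-fold lower number from compound 2 to compound 3 (0.14 log units; that floor lies within the scatter) as its step. Among the compounds with values here, both steps exchange a substituent on an aromatic carbon, and no measured step touches the group changed next. That change is 4-hydroxypiperidin-1-yl in place of 1,2,3,4-tetrahydroisoquinolin-2-yl on an aromatic carbon and it leads to compound 4 `O=S(=O)(c1ccc(F)cc1)c1nc2ccccc2nc1N1CCC(O)CC1` as the next structure. Within the data shown here, with a 1.1-fold higher number from compound 1 to compound 3 (0.04 log units; within the scatter) as the only numeric guide, no step beyond the scatter is expected, and the estimate is a 1.3-fold higher number from compound 3 to compound 4 (0.10 log units; within the scatter) in this assay on this untested change. Compound 4 is estimated at 45000 nM with an expected span from 18000 nM to 90000 nM for a measured number.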

Compound 4, half-maximal inhibitory concentration: 9580 nM
Compound 4: the middle estimate sits 4.7-fold (0.67 log units) above what was measured; measured number below the stated range.
By their numbers in this assay, from the lowest: compound 4; then compounds 1 and 3 (each within the scatter of the next). At a limit, above all of these: compound 2.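

In this assay, the place on the shared core next to the ring nitrogen responds to its substituent: 4-hydroxypiperidin-1-yl in place of 1,2,3,4-tetrahydroisoquinolin-2-yl gives a 3.7-fold lower number from compound 3 to compound 4 (0.57 log units; beyond the scatter). Within the data shown here, the exchanges on the aromatic carbon among compounds 1, 2 and 3 gave no step read as beyond the scatter, so this is the first place where a change clearly moves the number. No measurement shown bears on the cause of this step.

Going by these compounds, the change removes the fused aromatic ring and adds the hydroxyl at once, so the share of each stays open. Plain piperidin-1-yl, morpholin-4-yl or 4-aminopiperidin-1-yl at this place would separate them.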